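This account rests on a few compounds, and the source may have more. Where it says the series, first, only, none or still open, it means among the compounds named here.

Working notes on the series.

Of the compounds shown here, two have been measured. Compound 1 `c1nnc2nnc(N3CCCC3)nn12` carries a pyrrolidine on the shared core; in a functional assay on MCF7 cells (Homo sapiens) for inhibition, read by MTT assay, with a stated time of 72 h (on this read-out lower numbers stand for stronger inhibition and higher numbers for weaker inhibition), compound 1 gives 5130 nM. Compound 2 `CCCCCC(=O)N1CCN(c2nnc3nncn3n2)CC1` carries instead a piperazine bearing a pentylcarbonyl group; in this assay compound 2 gives 5260 nM. On these two numbers compound 2 sits at the same level as compound 1, the gap between them lying within the scatter, so nothing can be said of an order between the two.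

Compound 3 `CC(C)(C)C(=O)N1CCN(c2nnc3nncn3n2)CC1` is not yet measured. It differs from compound 2 in one place: tert-butyl in place of pentyl on a carbonyl carbon. The change is confined to the chain on the carbonyl carbon; the shared core and the amide-type nitrogen in the ring are untouched. Within the data shown here, no measured pair shows what such a change does, so there is no step to lean on.

With both measured compounds close together, the expectation for compound 3 is a step from compound 2 that stays within the scatter, a 1.0-fold higher number from compound 2 to compound 3 (0.02 log units; within the scatter), with no direction favoured. Compound 3 is therefore estimated at 5500 nM in this assay, within a range from 2500 nM to 12000 nM.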

Compound 3, half-maximal inhibitory concentration: 5510 nM
Beside the measured number, compound 3's estimate is 1.0-fold (0.00 log units) below it; the range from low to high includes it.
By their numbers in this assay, from the lowest: compounds 1, 2 and 3 (each within the scatter of the next).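

In this assay, among these compounds, the exchange of pentyl for tert-butyl on a carbonyl carbon gives the first measured step, which reads a 1.0-fold higher number from compound 2 to compound 3 (0.02 log units; within the scatter) and so does not separate the two chains. For this pair, a chain of 5 carbon and a chain of 4 carbon on the carbonyl carbon, with the amide-type nitrogen in the ring and the shared core untouched, leave the read-out at one level, a finding that extends to no other group. Nothing available on these compounds bears on why the two chains read alike.

Still open, on these data alone, is whether a different group on the same carbonyl carbon, such as an amine, a carboxylic acid, a phenyl ring or a much longer chain, would stay at this level or leave it. Also open is whether a change on the shared core itself would move the number, since the only step shown stays within the scatter and no step beyond it is yet available for comparison.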